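Shortening an alkoxy chain in hydrazide cytotoxicity on kidney cells

The compounds below may be only part of what the source reports. "The series", "measured", "known", "first", "only" and "open" are said of these compounds alone.

Measured compounds:
compound 1 `CCCOc1ccc(C(=O)NNc2c(Br)cccc2Br)cc1` — > 100000 nM
compound 2 `CCCCOc1ccc(C(=O)NNc2c(Br)cccc2Br)cc1` — > 100000 nM
compound 3 `CCOc1ccc(C(=O)NNc2c(F)cccc2F)cc1` — > 100000 nM

In a toxicity assay on MDCK cells (Canis lupus familiaris) for cytotoxicity, read by CCK-8 assay, with a stated time of 48 h (on this read-out higher numbers stand for lower toxicity in this test and lower numbers for higher toxicity in this test), compound 1 reaches only a limit of the test, > 100000 nM. In this assay compound 2 likewise gives only a limit, > 100000 nM. Compound 3 also stops at a limit, > 100000 nM. The change hydrogen in place of methyl on a saturated chain carbon, three bonds along the chain from an oxygen on an aromatic ring therefore gives a step that the two limits leave unreadable from compound 2 to compound 1. The difference between the cores of compound 3 and compound 2 is not broken down here. Compound 4 `COc1ccc(C(=O)NNc2c(F)cccc2F)cc1` carries the same kind of change, (hydrogen in place of methyl on a saturated chain carbon bound to an oxygen on an aromatic ring), but at a different place along the chain. Because (the limit of > 100000 nM in this assay, at which 3 of the 3 values shown sit), the step from compound 3 to compound 4 is expected to be small, a number no higher from compound 3 to compound 4 (the limit leaves the size open). Compound 4 is estimated at 100000 nM, between 40000 nM and 300000 nM.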

Compound 4, half-maximal cytotoxic concentration: > 100000 nM
Compound 4: only a limit was reported (the forecaster's own chance of this, stated with the estimate: 85%); the middle value lies on the limit itself.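

Compound 3 and compound 4 both stop at a limit of the test, and no step can be read between them. The compounds shown leave open where any of them would give a true number in this assay, and whether shortening the chain changes that number.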